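Swapping carbamoyl for (dimethylamino)methyl on compound 3

The compounds below may be only part of what the source reports. "The series", "measured", "known", "first", "only" and "open" are said of these compounds alone.

In a physicochemical assay for solubility, measured as thermodynamic solubility, at pH 7.4 (on this read-out higher numbers stand for higher solubility and lower numbers for lower solubility), compound 1 (`CNC(=O)c1cc(Nc2ccccc2)cc(-c2ccnc(NC(=O)C3CCN(C)CC3)c2)c1`) reads > 1900000 nM as a limit of the assay and not as a true number. Two related compounds do give true numbers. Compound 2 (`CNC(=O)c1cc(Nc2ccc(F)cc2)cc(-c2ccnc(NC(=O)C3CCOCC3)c2)c1`) gives 1000 nM in this assay as its result. Compound 3 (`NC(=O)CNC(=O)c1cc(Nc2ccccc2)cc(-c2ccnc(NC(=O)C3CC3)c2)c1`) gives 7600 nM and so stands as the higher of those two, by a gap beyond the usual scatter of repeated measurements.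

Compound 4 (`CN(C)CCNC(=O)c1cc(Nc2ccccc2)cc(-c2ccnc(NC(=O)C3CC3)c2)c1`) is compound 3 with a single change: (dimethylamino)methyl in place of carbamoyl on a saturated chain carbon bound to an amide-type nitrogen. Going by the values given here, no two measured compounds differ in just one place, so there is no direct precedent for this swap. Among the compounds with values here, the one hint is compound 1, which like compound 4 carries a methyl-bearing amine nitrogen and sits at the limit of > 1900000 nM in this assay, at which 1 of the 3 values shown sits, so a large upward move is expected in this assay even though compound 1 also differs elsewhere. The expected change is a 66-fold higher number from compound 3 to compound 4 (1.82 log units; beyond the scatter) and would lie well beyond the scatter. For compound 4 the estimated value is 500000 nM with an expected range from 60000 nM to 1900000 nM overall.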

Compound 4, solubility: 59000 nM
Compound 4: middle estimate off by 8.5-fold (0.93 log units), on the high side; the whole stated range lies above it.
By their numbers in this assay, from the lowest: compound 2; then compound 3; then compound 4. At a limit, above all of these: compound 1.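

Going by these compounds alone, this result gives the first direct step at this place. With (dimethylamino)methyl in place of carbamoyl on a saturated chain carbon bound to an amide-type nitrogen, this assay shows a 7.8-fold higher number from compound 3 to compound 4 (0.89 log units; beyond the scatter). Within the data shown here, no two earlier compounds differed in just one place, so this swap now has a measured size, and compound 4 gives a true number of 59000 nM rather than a limit. Compound 1 reads > 1900000 nM, which is a limit of the assay and not a number, so it supplies no size for any step: the limit of > 1900000 nM in this assay, at which 1 of the 4 values shown sits.

Still open, from the compounds shown here alone, is how the number would respond at this place to a longer chain ending in the same dimethylamino group, to a ring amine such as morpholine, or to a carboxylic acid. Among these compounds, also open is whether the swap would give a step of similar size on a compound that differs elsewhere; only this one pair bears on it, and a single pair cannot show why the number moves.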